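A few compounds are considered here, and "the series" means these few. Any claim that something is new, unique, unknown or untested is made for them only; others in the source may bear on it.

Compound 1 `CC(Cn1ccc(-c2ccc(C#N)c(Cl)c2)n1)C(=O)Nc1cccc(C(C)O)c1` was tested in an ADME assay on PC-3 cells (Homo sapiens) for cytotoxicity, read by CCK-8 assay, with a stated time of 6 days (on this read-out higher numbers stand for weaker inhibition and lower numbers for stronger inhibition), where it gives > 30000 nM, a limit of the assay rather than a number. Compound 2 `C[C@@H](Cn1ccc(-c2ccc(C#N)c(Cl)c2)n1)NS(=O)(=O)c1cccnc1` likewise gives > 30000 nM in this assay, again a limit. Among the compounds with values here, both values sit at the limit of > 30000 nM in this assay, at which 2 of the 2 values shown sit, so compound 2 stands exactly where every value so far stands. Compound 3 `C[C@@H](Cn1ccc(-c2ccc(C#N)c(Cl)c2)n1)Nc1ncccn1` differs from compound 2 in one place: pyrimidin-2-yl in place of (pyridin-3-yl)sulfonyl on an amine nitrogen. Within the data shown here, with no measured step to go by, the expected step from compound 2 to compound 3 is a number no higher from compound 2 to compound 3 (the limit leaves the size open), none beyond the scatter. Compound 3 is therefore estimated at 30000 nM in this assay, within 10000 nM to 100000 nM, and most likely reported only as a limit again.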

Compound 3, half-maximal inhibitory concentration: > 30000 nM
Compound 3: a limit, no number (the forecaster's own chance of this, stated with the estimate: 80%); the middle value sits exactly at the limit.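

Compound 2 and compound 3 each give only a limit in this assay, so no step between them can be read: the limit of > 30000 nM in this assay, at which 3 of the 3 values shown sit.

The compounds shown leave open whether pyrimidin-2-yl in place of (pyridin-3-yl)sulfonyl changes this read-out at all.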